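Compound 1 to compound 4: replacing the 2-chlorophenyl group

The source may report more compounds than this note shows. Statements on the series, on what has been measured and on what is new or still open speak of the compounds shown alone.

In a functional assay on HCT-15 cells (Homo sapiens) for cytotoxicity, in the presence of a further agent that is not named here (on this read-out higher numbers stand for weaker inhibition and lower numbers for stronger inhibition), compound 1 (`Clc1ccc(-c2cc(-c3ccsc3)nc(-c3ccccc3Cl)c2)o1`) gives 4570 nM. Compound 2 (`Clc1ccc(-c2cc(-c3cccs3)nc(-c3ccccc3Cl)c2)o1`) gives 6190 nM, and compound 3 (`Clc1cccc(-c2cc(-c3ccc(Cl)o3)cc(-c3cccs3)n2)c1`) gives 15500 nM. Compound 1 therefore stands level with compound 2, and the number for compound 3 is higher than both.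

Compound 4 (`Cc1ccc(-c2cc(-c3ccc(Cl)o3)cc(-c3ccsc3)n2)cc1`) keeps the core of compound 1 and carries 4-methylphenyl in place of 2-chlorophenyl on an aromatic carbon, next to the ring nitrogen: 4-methylphenyl in place of 2-chlorophenyl on an aromatic carbon.

Two measured steps can be weighed. Thiophen-2-yl in place of thiophen-3-yl gives a 1.4-fold higher number from compound 1 to compound 2 (0.13 log units; within the scatter), so the thiophene attachment shows no clear effect and the next step can reasonably be carried over to compound 1. Within the data shown here, only one step touches the changing place: 3-chlorophenyl in place of 2-chlorophenyl gives a 2.5-fold higher number from compound 2 to compound 3 (0.40 log units; beyond the scatter). Among the measured compounds shown here, no measured compound carries 4-methylphenyl, so this single modest step is only a rough guide. A modest step towards a higher number is expected in this assay, though a step within the scatter remains possible.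

The estimated change is a 2.0-fold higher number from compound 1 to compound 4 (0.29 log units; within the scatter). For compound 4 the expected value is 9000 nM, within an estimated range of 3500 nM to 23000 nM.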

Compound 4, half-maximal inhibitory concentration: 7410 nM
Beside the measured number, compound 4's estimate is 1.2-fold (0.08 log units) above it; low and high end bracket the measured number.
By their numbers in this assay, from the lowest: compounds 1, 2 and 4 (each within the scatter of the next); then compound 3.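

In this assay, among these compounds, the place on the aromatic carbon next to the ring nitrogen tolerates a larger change than the earlier compounds showed, with a 1.6-fold higher number from compound 1 to compound 4 (0.21 log units; within the scatter): the chlorine is gone from the phenyl ring, a methyl group takes its place on a different ring carbon, and the read-out stays within the scatter. Among the compounds shown here, the only earlier step at this place, a 2.5-fold higher number from compound 2 to compound 3 (0.40 log units; beyond the scatter), was a shift of the chlorine in the thiophen-2-yl compounds, so this result adds a first reading in the thiophen-3-yl compounds and shows that, with that group present, a chlorine on this phenyl ring is not needed to keep the number level with compound 1. No supporting data on hand account for this result.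

Still open is how far the two steps at this place can be joined, since 3-chlorophenyl and 4-methylphenyl are each read with a different thiophene attachment, and neither 4-methylphenyl with thiophen-2-yl nor 3-chlorophenyl with thiophen-3-yl appears among these compounds. Also open, on these data alone, is how the read-out would respond to an amine, a carboxylic acid or a longer chain on this phenyl ring, or to an unsubstituted phenyl group in the same place.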